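The source may report more compounds than this note shows. Statements on the series, on what has been measured and on what is new or still open speak of the compounds shown alone.

Measured compounds:
Compound 1 `C[C@H](O)[C@@H](CCc1ccc(C(F)(F)F)cc1)n1cnc2c(N)ncnc21` — in an assay on isolated protein for inhibition of adenosine deaminase (Bos taurus), with a stated time of 5 min (a higher number here means a weaker inhibitor, a lower number a stronger inhibitor), compound 1 gives 5.2 nM.
Compound 2 `C[C@H](O)[C@@H](CCC1CCCCC1)n1cnc2c(N)ncnc21` — in this assay compound 2 gives 1.9 nM.
Compound 3 `COC(=O)c1cccc(CC[C@H]([C@H](C)O)n2cnc3c(N)ncnc32)c1` — in this assay compound 3 gives 2.2 nM.

Among these three numbers compound 3 holds the second highest place. Its nearest neighbour is compound 2, whose value lies within the usual scatter of compound 3, so the two cannot be told apart on this evidence. The furthest is compound 1, whose higher number stands beyond the scatter, so compound 3 is the stronger inhibitor of that pair.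

Compound 4 `CNC(=O)c1cccc(CC[C@H]([C@H](C)O)n2cnc3c(N)ncnc32)c1` is the next compound to be measured. It differs from compound 3 in one place: methylamino in place of methoxy on a carbonyl carbon. Read one bond further out, the change is methoxycarbonyl to methylcarbamoyl.

Among the measured compounds shown here, no pair of measured compounds shows a step of this kind, so the size of the step can only be guessed from the spread of the three values, which is narrow. The expectation is that compound 4 stays close to compound 3, with a step of a 1.4-fold higher number from compound 3 to compound 4 (0.13 log units; within the scatter), which is not expected to go beyond the scatter. For compound 4 the estimated value in this assay is 3 nM, with a range from 1.2 nM to 8 nM.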

Compound 4, inhibition constant: 2.7 nM
Beside the measured number, compound 4's estimate is 1.1-fold (0.05 log units) above it; the measured number falls inside the stated range.
By their numbers in this assay, from the lowest: compounds 2, 3, 4 and 1 (each within the scatter of the next, the first and the last beyond it).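

Read in this assay, the exchange of methoxy for methylamino on a carbonyl carbon gives a 1.2-fold higher number from compound 3 to compound 4 (0.09 log units; within the scatter), the first step in this set between compounds that differ in one place. On this evidence the two groups cannot be told apart at this carbonyl carbon, even though the counts differ: methylamino has 1 hydrogen-bond donor and 0 hydrogen-bond acceptors, while methoxy has 0 hydrogen-bond donors and 1 hydrogen-bond acceptor. No supporting measurement is available to explain why the two groups read alike.

Only these two groups are seen on this carbonyl carbon, so the compounds shown leave open whether a hydroxyl group, giving the free carboxylic acid, a dimethylamino group or a longer chain such as ethoxy would also stay within the scatter of compound 3. Among the compounds shown here, they also leave open whether the same exchange would give a step of similar size elsewhere, since this single pair is the only reading of it.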